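Removing a Methoxy Group from the Weakest Binder

The source may report more compounds than this note shows. Statements on the series, on what has been measured and on what is new or still open speak of the compounds shown alone.

Compound 1 `COc1ccc(-n2c(=O)n(CCN3CCN(c4ccccc4)CC3)c3ccccc32)cc1` has the highest number of the three compounds measured in an assay on HEK293 cells for displacement of a labelled ligand from 5-hydroxytryptamine receptor 7 (Homo sapiens) (on this read-out higher numbers stand for weaker inhibition and lower numbers for stronger inhibition), where compound 1 gives 566 nM, clearly apart from the other two. Compound 2 `COc1ccccc1N1CCN(CCCCn2c(=O)[nH]c3ccccc32)CC1` gives 26 nM and compound 3 `O=c1[nH]c2ccccc2n1CCCCN1CCN(c2ccccc2)CC1` gives 48 nM. Compound 4 `O=c1n(CCN2CCN(c3ccccc3)CC2)c2ccccc2n1-c1ccccc1` differs from compound 1 in a single place: hydrogen in place of methoxy on an aromatic carbon. The same kind of swap is already known from one measured pair, although at a different site in the molecule, and there it gave a 1.8-fold higher number from compound 2 to compound 3 (0.27 log units; within the scatter). On that basis a comparably small change is expected here, not beyond the scatter, if anything toward a slightly higher number, so the expected step is a 1.2-fold higher number from compound 1 to compound 4 (0.09 log units; within the scatter). Compound 4 is therefore estimated at 700 nM, with a likely range from 250 nM to 1900 nM.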

Compound 4, inhibition constant: 1230 nM
The estimate for compound 4 lay 1.8-fold (0.24 log units) below the measured number; the measured number falls inside the stated range.
By their numbers in this assay, from the lowest: compounds 2 and 3 (each within the scatter of the next); then compound 1; then compound 4.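

In this assay, changing 4-methoxyphenyl to phenyl gives a 2.2-fold higher number from compound 1 to compound 4 (0.34 log units; beyond the scatter), so at this position the methoxy makes a modest difference that can be told from the scatter. Set side by side, the same swap on two cores gives steps that agree in size: the same change on two cores in this assay, a 1.8-fold higher number (0.27 log units; within the scatter) from compound 2 to compound 3 and a 2.2-fold higher number (0.34 log units; beyond the scatter) from compound 1 to compound 4, 1.2-fold (0.07 log units) apart, within the scatter of two such steps

From the compounds shown here alone, what remains open is how other groups in this place on the ring, such as a hydroxyl, a chlorine atom or an amine, would compare with methoxy and hydrogen. The compounds shown also leave open whether any group here could bring the number on this core close to those of compound 2 and compound 3.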